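The compounds below may be only part of what the source reports. "The series", "measured", "known", "first", "only" and "open" are said of these compounds alone.

Working notes on the series in a functional assay on SMMC-7721 cells (Homo sapiens) for cytotoxicity, read by MTT assay, with a stated time of 4 days; a lower number here means a stronger inhibitor, a higher number a weaker inhibitor. Among the measured compounds shown here, compound 1 `C=C1C[C@]23C[C@@]1(O)CC[C@H]2c1ccc(OS(=O)(=O)c2ccc(C)cc2)c(C)c1[C@@H]3Cn1cc(-c2ccccc2)nn1` is the first member. In this assay compound 1 gives only the assay limit, > 20000 nM. Compound 2 `C=C1C(=O)[C@]23C[C@@]1(O)CC[C@H]2c1ccc(O)c(C)c1[C@@H]3Cn1cc(-c2ccc(C(F)(F)F)cc2)nn1`, the second member, gives 1440 nM in this assay. For the measured compounds named here, compound 2 therefore holds the only actual number in the set so far. The other value sits at the limit described by the limit of > 20000 nM in this assay, at which 1 of the 2 values shown sits. Going by the values given here, no step between two measured compounds differing in one place is available, so there is no measured evidence yet on how large a single change moves the number here. Compound 3 `C=C1C(=O)[C@]23C[C@@]1(O)CC[C@H]2c1ccc(O)c(C)c1[C@@H]3Cn1cc(-c2ccc(Cl)cc2)nn1` differs from compound 2 by chloro in place of trifluoromethyl on an aromatic carbon; cut one bond further out, the difference reads as 4-(trifluoromethyl)phenyl to 4-chlorophenyl, and the changed carbon is para to a large group. A change of this kind, without any measured step behind it, is expected to stay within the usual scatter, in no particular direction: the expected step is a 1.3-fold higher number from compound 2 to compound 3 (0.10 log units; within the scatter). Compound 3 is accordingly estimated at 1800 nM in this assay, within 700 nM to 4500 nM.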

Compound 3, half-maximal inhibitory concentration: 670 nM
For compound 3 the middle estimate is 2.7-fold (0.43 log units) above the measured one; measured number below the stated range.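

In this assay the series now has its first step between two measured compounds that differ in one place: a 2.1-fold lower number from compound 2 to compound 3 (0.33 log units; beyond the scatter), with chloro in place of trifluoromethyl on an aromatic carbon, para to a large group. The number at this position therefore responds to the substituent, since this exchange gives a modest step beyond the scatter even though the count of hydrogen-bond donors and acceptors stays the same and neither group carries a net charge. No measurement shown bears on why the number moves with this exchange.

Going by these compounds, this single pair sets no trend, and it remains open how the number responds when an amine, a carboxylic acid or a longer chain stands at the same place on the phenyl ring of the 4-chlorophenyl group. Compound 1 gives only an assay limit, > 20000 nM, and it differs from the other compounds in more than one place, so it cannot show what any single one of those differences contributes.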